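This account rests on a few compounds, and the source may have more. Where it says the series, first, only, none or still open, it means among the compounds named here.

Three compounds have been measured in an assay on a protein complex for inhibition of CDK8/Cyclin C (Homo sapiens), with a stated time of 1 h, tested at 10 uM; a higher number here means more inhibition at the concentration tested (going by the name of the read-out), a lower number less inhibition:

compound 1, `NNC(=O)COc1ccncc1-c1ccc2ccccc2c1`: 19%
compound 2, `CCOC(=O)/C=C/c1ccncc1-c1ccc2cc[nH]c2c1`: 104%
compound 3, `CN1CCN(c2ccc(Nc3cnccc3/C=C/C(N)=O)cc2)CC1`: 75%

Among these three numbers compound 1 stands lowest. Its nearest neighbour is compound 3, whose value lies well beyond the scatter above it, and compound 2 lies further still, also beyond the scatter. Among the measured compounds shown here, no pair of these measured compounds differs in a single place, so no measured step is available to show how one change shifts the read-out.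

Compound 4, `COC(=O)CCc1ccncc1-c1ccc2ccccc2c1`, has not yet been measured. It differs from compound 1 in one place: 2-(methoxycarbonyl)ethyl in place of (aminocarbamoyl)methoxy on an aromatic carbon. The only anchor for an expectation is compound 1 itself, with its 19% in this assay, since nothing measured tells what this exchange of one six-heavy-atom chain for another does.

For the measured compounds named here, with no comparable step to lean on, the estimate stays close to compound 1. Compound 4 is expected to give 25% in this assay, within a range from 5% to 55%. The step from compound 1 to compound 4 is thus expected to be a number 6 percentage points higher from compound 1 to compound 4 (within the scatter), a shift that would stay within the usual scatter.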

Compound 4, a percentage reported as inhibition, at one concentration (the size of the read-out at that concentration, not a potency): 98%
Estimate against measurement, compound 4: 73 percentage points below, and the stated range ends below it.
By their numbers in this assay, from the lowest: compound 1; then compound 3; then compounds 4 and 2 (each within the scatter of the next).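

Among the compounds shown here, this is the first measured single change in the set, and it shows that the group on this aromatic carbon, ortho to a large group and opposite the ring nitrogen, strongly affects the result in this assay: with the rest of the molecule unchanged, the read-out is a number 79 percentage points higher from compound 1 to compound 4 (beyond the scatter). The two chains hold the same number of heavy atoms and neither has a ring, so this large step comes with a change in what the chain is made of, not in how many heavy atoms it holds: 2-(methoxycarbonyl)ethyl has no nitrogen and no hydrogen-bond donors, while (aminocarbamoyl)methoxy has both. No measurement at hand gives a reason for this step.

The compounds shown leave open which difference matters, whether it is the aminocarbamoyl end, the methoxycarbonyl end, or the oxygen that joins (aminocarbamoyl)methoxy to the ring. Going by these compounds, a carboxylic acid at the end of the chain, or a longer chain with the same methoxycarbonyl end, on this same core would help separate these possibilities, and whether the step carries over to a different core also remains open.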